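The source may hold more compounds than are shown below. What is called first, only, known or untested is meant among the compounds shown, and "the series" means these compounds.

Compound 1 `CNc1nc(C)c(-c2nc3cnccc3s2)c(N[C@@H]2C[C@H](CO)[C@@H](O)[C@H]2O)n1`: 14000 nM
Compound 2 `Cc1nc(NCc2c(F)cccc2F)nc(N[C@@H]2C[C@H](CO)[C@@H](O)[C@H]2O)c1-c1nc2cnccc2s1`: 4000 nM
Compound 3 `Cc1ccc(C2(Nc3nc(C)c(-c4nc5cnccc5s4)c(N[C@@H]4C[C@H](CO)[C@@H](O)[C@H]4O)n3)CC2)cc1`: 25000 nM

All three were tested in an ADME assay on cells (Homo sapiens) for cytotoxicity, read by polymerase chain reaction, with a stated time of 3 days; on this read-out higher numbers stand for lower toxicity in this test and lower numbers for higher toxicity in this test. Compound 1 stands second highest of the three numbers; its nearest neighbour is compound 3, at a 1.8-fold higher number from compound 1 to compound 3 (0.25 log units; within the scatter), while compound 2 lies further off, at a 3.5-fold lower number from compound 1 to compound 2 (0.54 log units; beyond the scatter). Compound 4 `Cc1ccc([C@@H](C)Nc2nc(C)c(-c3nc4cnccc4s3)c(N[C@@H]3C[C@H](CO)[C@@H](O)[C@H]3O)n2)cc1` has not yet been measured. It differs from compound 1 in one place: 1-(4-methylphenyl)ethyl in place of methyl on a nitrogen on an aromatic ring. Among the compounds with values here, the closest measured step is the one from compound 1 to compound 3, where the 1-(4-methylphenyl)cyclopropyl group entered on a nitrogen on an aromatic ring and the number stayed within the scatter. The step from compound 1 to compound 2, a different change at a different nitrogen, lowered the number modestly. Weighing these, compound 4 is expected to move by a 1.1-fold higher number from compound 1 to compound 4 (0.03 log units; within the scatter), within the scatter. Compound 4 is therefore estimated at 15000 nM, with a range from 5000 nM to 40000 nM.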

Compound 4, half-maximal cytotoxic concentration: 25000 nM
The estimate for compound 4 lay 1.7-fold (0.22 log units) below the measured number, within the range that was stated.
By their numbers in this assay, from the lowest: compound 2; then compounds 1, 3 and 4 (each within the scatter of the next).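

In this assay, the 1-(4-methylphenyl)ethyl group on the nitrogen stays within the scatter of methyl (a 1.8-fold higher number from compound 1 to compound 4 (0.25 log units; within the scatter)) and of 1-(4-methylphenyl)cyclopropyl (no change at the digits printed from compound 3 to compound 4 (within the scatter)), so the cyclopropyl ring is not needed for this number. Among the groups shown, only 2,6-difluorobenzyl stands apart (a 6.3-fold higher number from compound 2 to compound 4 (0.80 log units; beyond the scatter)), and it goes against any reading that large groups here simply match methyl. No measurement at hand explains that gap. Open, on these data alone, is whether the mirror-image 1-(4-methylphenyl)ethyl group, an unfluorinated benzyl group or a chain ending in an amine would give a similar number.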